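The compounds below may be only part of what the source reports. "The series", "measured", "known", "first", "only" and "open" are said of these compounds alone.

Three compounds sharing one core went into a functional assay on G-361 cells (Homo sapiens) for antiproliferative activity, with a stated time of 72 h (a higher number here means a weaker inhibitor, a lower number a stronger inhibitor), and the record is thin. Compound 1 (`OC[C@H]1O[C@@H](n2cnc3c(NCc4ccccc4F)ncnc32)[C@H](O)[C@@H]1O`) has "not determined" (no result reported) as its entry. Compound 2 (`OC[C@H]1O[C@@H](n2cnc3c(NCc4ccccc4Cl)ncnc32)[C@H](O)[C@@H]1O`) has "not determined" (no result reported) as its entry. Compound 3 (`OC[C@H]1O[C@@H](n2cnc3c(NCc4ccc(F)cc4Cl)ncnc32)[C@H](O)[C@@H]1O`) has > 166000 nM as its entry, which is a limit of the assay and not a number. The only anchor is therefore the limit of > 166000 nM in this assay, at which 1 of the 3 values shown sits, and nothing more. Compound 4 (`OC[C@H]1O[C@@H](n2cnc3c(NCc4cc(O)cc(O)c4)ncnc32)[C@H](O)[C@@H]1O`) carries 3,5-dihydroxyphenyl in place of 2-chloro-4-fluorophenyl on a saturated chain carbon bound to a nitrogen on an aromatic ring. Among the measured compounds shown here, no measured step guides this change in this assay. The expected move is toward stronger inhibition, an estimated at least 4.1-fold lower number from compound 3 to compound 4 (0.61 log units; beyond the scatter) in rough terms. For compound 4 the estimated value is 40000 nM with an expected range from 5000 nM to 166000 nM as a rough guide.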

Compound 4, half-maximal inhibitory concentration: > 166000 nM
Compound 4 gave a limit, no number; the forecaster's own chance of this, stated with the estimate: 40%; at least 4.1-fold (0.61 log units) between middle value and limit.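

No step from compound 3 to compound 4 can be read, since each gives only a limit in this assay: the limit of > 166000 nM in this assay, at which 2 of the 4 values shown sit.

The compounds shown leave open whether 2-chloro-4-fluorobenzyl and 3,5-dihydroxybenzyl differ at all in antiproliferative activity.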